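A few compounds are considered here, and "the series" means these few. Any claim that something is new, unique, unknown or untested is made for them only; others in the source may bear on it.

Measured in an ADME assay (liver) for metabolic stability, with Liver microsome (Homo sapiens) as the target, using microsomes and NADPH, with a stated time of 30 min, tested at 1 uM; a lower number here means slower removal, a higher number faster removal of the compound:
Compound 1 `Nc1ccc(S(=O)(=O)N2CCN(c3ncc(C(O)(C(F)(F)F)C(F)(F)F)cc3Br)CC2)cn1`: < 14 mL.min-1.g-1, a limit
Compound 2 `Nc1ccc(S(=O)(=O)N2CCN(c3ncc(C(O)(C(F)(F)F)C(F)(F)F)cc3C#CCCO)CC2)cn1`: < 14 mL.min-1.g-1, a limit
Compound 3 `Nc1ccc(S(=O)(=O)N2CCN(c3ncc(C(O)(C(F)(F)F)C(F)(F)F)cc3-c3cccc(F)c3)CC2)cn1`: 25 mL.min-1.g-1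

Within the data shown here, compound 3 gives the only actual number, 25 mL.min-1.g-1. The other two compounds sit at the limit of < 14 mL.min-1.g-1 in this assay, at which 2 of the 3 values shown sit. Compound 4 `NC(=O)c1cccc(-c2cc(C(O)(C(F)(F)F)C(F)(F)F)cnc2N2CCN(S(=O)(=O)c3ccc(N)nc3)CC2)c1` differs from compound 3 by carbamoyl in place of fluoro on an aromatic carbon, which turns 3-fluorophenyl into 3-carbamoylphenyl. Among the measured compounds shown here, no measured step changes this place. The two nearest steps bring in 3-fluorophenyl: an at least 1.7-fold higher number from compound 1 to compound 3 (0.25 log units; that floor lies within the scatter) and an at least 1.7-fold higher number from compound 2 to compound 3 (0.25 log units; that floor lies within the scatter). Neither measures carbamoyl, so the estimate starts from compound 3 at 25 mL.min-1.g-1. A small expected step toward a lower number in this assay is estimated as a 1.6-fold lower number from compound 3 to compound 4 (0.19 log units; within the scatter). For compound 4 the estimated value is 16 mL.min-1.g-1, with an expected range of 10 mL.min-1.g-1 to 28 mL.min-1.g-1.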

Compound 4, intrinsic clearance in microsomes: 17 mL.min-1.g-1
Compound 4: the middle estimate sits 1.1-fold (0.03 log units) below what was measured; the range from low to high includes it.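

In this assay, a change within the 3-fluorophenyl group itself can now be read: a 1.5-fold lower number from compound 3 to compound 4 (0.17 log units; within the scatter) lies within the scatter, so carbamoyl in place of fluoro gives no readable difference at this place. Only floors are available against the bromo and 4-hydroxybut-1-yn-1-yl groups, an at least 1.2-fold higher number from compound 1 to compound 4 (0.08 log units; that floor lies within the scatter) and an at least 1.2-fold higher number from compound 2 to compound 4 (0.08 log units; that floor lies within the scatter), and both floors lie within the scatter. Compound 1 and compound 2 each hold a limit rather than a number: the limit of < 14 mL.min-1.g-1 in this assay, at which 2 of the 4 values shown sit.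

Going by these compounds, how far 3-carbamoylphenyl truly stands from those two groups stays open. So does whether an amine or a carboxylic acid in place of fluoro would give a step beyond the scatter.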